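Swapping Acetyl for Methyl on a Sulfur

The source may report more compounds than this note shows. Statements on the series, on what has been measured and on what is new or still open speak of the compounds shown alone.

In a functional assay on HCT-116 cells (Homo sapiens) for inhibition, read by MTT assay, with a stated time of 96 h (a higher number here means a weaker inhibitor of growth, a lower number a stronger inhibitor of growth), compound 1 `CC(C)C(=O)SCCCCCCNC(=O)c1cc(-c2ccncc2)n[nH]1` gives 22700 nM, compound 2 `CCCC(=O)SCCCCCCNC(=O)c1cc(-c2ccncc2)n[nH]1` gives 23500 nM, and compound 3 `CC(=O)SCCCCCCNC(=O)c1cc(-c2ccncc2)n[nH]1` gives 41100 nM. Compound 3 therefore stands level with the other two, as all the steps are small: a 1.8-fold higher number from compound 1 to compound 3 (0.26 log units; within the scatter), a 1.7-fold higher number from compound 2 to compound 3 (0.24 log units; within the scatter) and a 1.0-fold higher number from compound 1 to compound 2 (0.02 log units; within the scatter). Compound 4 `CSCCCCCCNC(=O)c1cc(-c2ccncc2)n[nH]1` has methyl in place of acetyl on a sulfur. Each measured step only alters the group on the carbonyl carbon, and none removes the carbonyl, so they offer little guidance here. A move to a higher number, beyond the scatter, is nevertheless expected, though its size is uncertain. The estimated step runs a 1.7-fold higher number from compound 3 to compound 4 (0.23 log units; within the scatter). Compound 4 is expected at 70000 nM, within a range of 30000 nM to 150000 nM.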

Compound 4, concentration for 50% growth inhibition: > 50000 nM
Compound 4 ended at the assay's limit (the forecaster's own chance of this, stated with the estimate: 40%); the middle value lies beyond the limit too.
By their numbers in this assay, from the lowest: compounds 1, 2 and 3 (each within the scatter of the next). At a limit, above all of these: compound 4.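

Compound 4 gives > 50000 nM in this assay, which is a limit of the assay and not a number: the limit of > 50000 nM in this assay, at which 1 of the 4 values shown sits.

Among these compounds, replacing the carbonyl-bearing group on the sulfur with methyl produces the first steps here that pass the scatter, an at least 2.1-fold higher number from compound 2 to compound 4 (0.32 log units; beyond the scatter) and an at least 2.2-fold higher number from compound 1 to compound 4 (0.34 log units; beyond the scatter). The step closest to this change, an at least 1.2-fold higher number from compound 3 to compound 4 (0.08 log units; that floor lies within the scatter), gives only a floor, so it shows no clear shift on its own.

Going by these compounds, how far compound 4 truly lies from compound 3 stays open. So does the effect of a free thiol, an amine or a longer chain on the sulfur.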